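The source may hold more compounds than are shown below. What is called first, only, known or untested is meant among the compounds shown, and "the series" means these compounds.

Measured so far in an assay on membranes from spleen (Cavia porcellus) for binding affinity to leukotriene B4 receptor 1 (Homo sapiens); on this read-out lower numbers stand for stronger inhibition and higher numbers for weaker inhibition:
compound 1 `O=C(O)CCCCCCOc1cc(-c2ccccc2)c2ccccc2n1` gives 1800 nM
compound 2 `CC(CCCCOc1cc(-c2ccccc2)c2ccccc2n1)C(=O)O` gives 550 nM

Compound 2 stands lowest of the two numbers; its nearest neighbour is compound 1, with the step of a 3.3-fold lower number from compound 1 to compound 2 (0.51 log units; beyond the scatter) lying beyond the scatter.

Compound 3 `c1ccc(-c2cc(OCCCCCc3nnn[nH]3)nc3ccccc23)cc1` is not yet measured. Its difference from compound 2 is (1H-tetrazol-5-yl)methyl in place of 1-carboxyethyl on a saturated chain carbon, four bonds along the chain from an oxygen on an aromatic ring. Within the data shown here, no measured step bears on this exchange: the one step known, a 3.3-fold lower number from compound 1 to compound 2 (0.51 log units; beyond the scatter), concerns only branching on the chain and is modest in size. Among the measured compounds shown here, with no comparable step available, no shift beyond the scatter is expected in this assay, so the estimated step of a 1.1-fold higher number from compound 2 to compound 3 (0.04 log units; within the scatter) is near nil. Compound 3 is expected at 600 nM, within 200 nM to 2000 nM.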

Compound 3, half-maximal inhibitory concentration: 500 nM
Compound 3: the middle estimate sits 1.2-fold (0.08 log units) above what was measured, within the range that was stated.
By their numbers in this assay, from the lowest: compounds 3 and 2 (each within the scatter of the next); then compound 1.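

In this assay, (1H-tetrazol-5-yl)methyl in place of 1-carboxyethyl at this chain carbon gives a 1.1-fold lower number from compound 2 to compound 3 (0.04 log units; within the scatter), so the two groups cannot be told apart on this read-out. Read against the unbranched acid, 1H-tetrazol-5-yl in place of carboxymethyl gives a 3.6-fold lower number from compound 1 to compound 3 (0.56 log units; beyond the scatter), which shows that an unbranched chain ending in the tetrazole reaches the level of the branched acid. Nothing at hand explains either step. Open, as far as these compounds go, is whether a methyl branch on the chain of compound 3 would lower the number further, and whether a sulfonamide or a longer chain would be tolerated at this position.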